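Methyl Branching on the Acid Chain of Two Cores

The source may hold more compounds than are shown below. What is called first, only, known or untested is meant among the compounds shown, and "the series" means these compounds.

Three compounds bearing the same acid side chain were tested in a functional assay on CHO cells for antagonist activity at sphingosine 1-phosphate receptor 2 (Homo sapiens), read by GTPgammaS binding; on this read-out higher numbers stand for weaker inhibition and lower numbers for stronger inhibition. Compound 3 `O=C(O)Cc1nn(Cc2cn3cc(OCC4CC4)c(Cl)cc3n2)c2ccccc2c1=O` gives 30 nM, and compound 2 `O=C(O)Cn1nc(Cn2cc3cc(OCC4CC4)c(Cl)cc3n2)c2ccccc2c1=O` gives 53 nM in this assay; the difference between the two cores is not broken down here, and the two values lie within the scatter. Compound 1 `C[C@@H](C(=O)O)c1nn(Cc2cn3cc(OCC4CC4)c(Cl)cc3n2)c2ccccc2c1=O` gives 253 nM in this assay; it differs from compound 3 by methyl in place of hydrogen on a saturated chain carbon bound to an aromatic carbon and a carbonyl carbon, which made an 8.4-fold higher number from compound 3 to compound 1 (0.93 log units; beyond the scatter). Compound 4 `C[C@H](C(=O)O)n1nc(Cn2cc3cc(OCC4CC4)c(Cl)cc3n2)c2ccccc2c1=O` differs from compound 2 by methyl in place of hydrogen on a saturated chain carbon bound to an aromatic nitrogen and a carbonyl carbon. The place is not identical, the chain carbon being bound to an aromatic nitrogen rather than an aromatic carbon, so this is the same kind of change, not the same one. Because an 8.4-fold higher number from compound 3 to compound 1 (0.93 log units; beyond the scatter) was seen, the expected step is a 5.7-fold higher number from compound 2 to compound 4 (0.75 log units; beyond the scatter), with some allowance for the altered place. Compound 4 is estimated at 300 nM, between 100 nM and 900 nM.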

Compound 4, half-maximal inhibitory concentration: 15 nM
Compound 4: middle estimate off by 20-fold (1.30 log units), on the high side; the whole stated range lies above it.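

In this assay the methyl in place of hydrogen gave a 3.5-fold lower number from compound 2 to compound 4 (0.55 log units; beyond the scatter), the opposite direction to its effect on the other core. The two steps differ by more than scatter can explain: the same change on two cores in this assay, an 8.4-fold higher number (0.93 log units; beyond the scatter) from compound 3 to compound 1 and a 3.5-fold lower number (0.55 log units; beyond the scatter) from compound 2 to compound 4, 30-fold (1.47 log units) apart, beyond the scatter of two such steps. Among these compounds, this shows that the effect of the change did not carry from the core of compound 3 to the core of compound 2, but with only one pair per core it does not show why, and the chain carbon also sits on an aromatic nitrogen in one pair and an aromatic carbon in the other.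

Going by these compounds, what an ethyl group or a second methyl on that chain carbon would do on either core stays open. So does the opposite configuration at the branched carbon of compound 1 and compound 4.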